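Furan, thiophene and phenyl at one aromatic carbon

The compounds below may be only part of what the source reports. "The series", "measured", "known", "first", "only" and "open" are said of these compounds alone.

Values in an ADME assay on MRC5 cells (Homo sapiens), read by MTT assay, with a stated time of 72 h; a higher number here means a weaker inhibitor, a lower number a stronger inhibitor:
- Compound 1 `COc1nc(N)nc2c1c(-c1ccco1)cn2[C@@H]1O[C@H](CO)[C@@H](O)[C@H]1O`: 89700 nM
- Compound 2 `COc1nc(N)nc2c1c(-c1ccsc1)cn2[C@@H]1O[C@H](CO)[C@@H](O)[C@H]1O`: > 100000 nM

Compound 2 gives > 100000 nM, which is a limit of the assay and not a number. Its standing is therefore given only by the limit of > 100000 nM in this assay, at which 1 of the 2 values shown sits.

The next change leads to compound 3 `COc1nc(N)nc2c1c(-c1ccccc1)cn2[C@@H]1O[C@H](CO)[C@@H](O)[C@H]1O`, with phenyl in place of thiophen-3-yl on an aromatic carbon.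

Among the measured compounds shown here, one measured step bears on this change, at the same aromatic carbon of the shared core: an at least 1.1-fold higher number from compound 1 to compound 2 (0.04 log units; that floor lies within the scatter). That step rests on a limit and stays within the scatter, so no step beyond the scatter is expected in this assay, in either direction.

Compound 3 is estimated at 90000 nM, with an expected range of 35000 nM to 130000 nM. The expected step is an at least 1.1-fold lower number from compound 2 to compound 3 (0.04 log units; that floor lies within the scatter).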

Compound 3, half-maximal inhibitory concentration: > 100000 nM
Compound 3: a limit, no number; the forecaster's own chance of this, stated with the estimate: 45%; middle value at least 1.1-fold (0.04 log units) from the limit.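

In this assay compound 3, with phenyl on this aromatic carbon, gives > 100000 nM, which is a limit of the assay and not a number. Against the furan-2-yl of the shared core, the change gives an at least 1.1-fold higher number from compound 1 to compound 3 (0.04 log units; that floor lies within the scatter), so a six-membered aromatic ring of carbon only has so far produced no step beyond the scatter at this position. The step between thiophen-3-yl and phenyl cannot be read, and the series now offers little resolution at this end of the assay: the limit of > 100000 nM in this assay, at which 2 of the 3 values shown sit.

From the compounds shown here alone, how far compound 2 and compound 3 lie past the limit stays open. Also open, going by these compounds, is whether an amine, a carboxylic acid or a longer chain on this aromatic carbon would give a step beyond the scatter in either direction.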